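Oxazole Substituent Swap on a Hydroxyalkyl Chain Series

The source may hold more compounds than are shown below. What is called first, only, known or untested is meant among the compounds shown, and "the series" means these compounds.

Compound 1 `O=C(CCCCCCc1ccccc1)c1ncc(C(=O)N2CCOCC2)o1` gives 24 nM in an assay (Rattus norvegicus) for inhibition of Fatty-acid amide hydrolase 1 (Homo sapiens); a higher number here means a weaker inhibitor, a lower number a stronger inhibitor.
Compound 2 `N#Cc1cnc(C(O)CCCCCCc2ccccc2)o1` gives 4200 nM in this assay.
Compound 3 `OC(CCCCCCc1ccccc1)c1ncc(C(F)(F)F)o1` gives 2300 nM in this assay.

Compound 3 stands second highest of the three numbers shown. Its nearest neighbour is compound 2, whose number sits higher, and the step of a 1.8-fold lower number from compound 2 to compound 3 (0.26 log units; within the scatter) shows that exchanging cyano for trifluoromethyl on the aromatic carbon moved the number little. Compound 1, by contrast, carries a ketone and a morpholine amide rather than an alcohol and lies far lower in this assay.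

Compound 4 `COC(=O)c1cnc(C(O)CCCCCCc2ccccc2)o1` keeps the alcohol and the chain of compound 3 and differs only in the substituent on the five-membered aromatic ring: methoxycarbonyl in place of trifluoromethyl on an aromatic carbon. Going by the values given here, no measured step involves methoxycarbonyl, so the only step that bears on this change is the one from compound 2 to compound 3, in which a swap of one small group for another at the same aromatic carbon stayed within the scatter. Among the compounds with values here, on that basis compound 4 is expected to stay close to compound 3 in this assay, with the step of a 1.3-fold lower number from compound 3 to compound 4 (0.11 log units; within the scatter) estimated to lie within the scatter, though the range is wide given that only one comparable step exists. Compound 4 is therefore estimated at 1800 nM, within a range of 450 nM to 7000 nM.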

Compound 4, inhibition constant: 2000 nM
For compound 4 the middle estimate is 1.1-fold (0.05 log units) below the measured one; the measured number falls inside the stated range.
By their numbers in this assay, from the lowest: compound 1; then compounds 4, 3 and 2 (each within the scatter of the next, the first and the last beyond it).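

Methoxycarbonyl is the first group at this aromatic carbon, next to the ring oxygen, to bring hydrogen-bond acceptors and a double bond outside aromatic rings, yet in this assay the replacement of trifluoromethyl gives a 1.2-fold lower number from compound 3 to compound 4 (0.06 log units; within the scatter) and so does not separate the two groups. The comparison with cyano reads slightly differently, with a 2.1-fold lower number from compound 2 to compound 4 (0.32 log units; beyond the scatter) as a modest step just past the scatter, although trifluoromethyl and cyano themselves could not be separated, with a 1.8-fold lower number from compound 2 to compound 3 (0.26 log units; within the scatter) on record. All three groups therefore leave the alcohol series in one narrow band of numbers, and nothing given here offers a reason for that.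

Compound 4 and compound 1 differ in two places, so the distance to the value of compound 1, 24 nM, cannot be divided between the ketone and the morpholine amide. Going by these compounds, what stays open is how a carboxylic acid or an amine would read at this aromatic carbon, and whether methoxycarbonyl would hold its place in the band if the alcohol were exchanged for the ketone.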